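Swapping Hydroxy for Chloro on the Aryl Ketone

A few compounds are considered here, and "the series" means these few. Any claim that something is new, unique, unknown or untested is made for them only; others in the source may bear on it.

Of the compounds shown here, two sharing one core have been tested in a functional assay on SF-539 cells (Homo sapiens) for cytotoxicity, read by sulforhodamine B assay, with a stated time of 24 h; a higher number here means a weaker inhibitor of growth, a lower number a stronger inhibitor of growth. Compound 1 `COc1ccc(C(=O)/C=C/c2cc3ccccc3[nH]c2=O)cc1` gives 2760 nM, and compound 2 `O=C(/C=C/c1cc2ccccc2[nH]c1=O)c1ccc(O)cc1` gives 2550 nM. The step of a 1.1-fold lower number from compound 1 to compound 2 (0.03 log units; within the scatter) shows that exchanging methyl for hydrogen on the ring oxygen leaves the result essentially unchanged; compound 2 holds the lower of the two numbers, but the gap is within the scatter, so neither compound can be called the stronger inhibitor. Compound 3 `O=C(/C=C/c1cc2ccccc2[nH]c1=O)c1ccc(Cl)cc1` has not yet been measured. It differs from compound 2 in one place: chloro in place of hydroxy on an aromatic carbon. Among the measured compounds shown here, only the single measured step bears on this change, and it was within the scatter; since the same position is altered again, a step in this assay of no more than the scatter is expected, in no preferred direction. For compound 3, a value of 2500 nM is expected, with a range from 1000 nM to 6000 nM. This expectation corresponds to the step of a 1.0-fold lower number from compound 2 to compound 3 (0.01 log units; within the scatter).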

Compound 3, concentration for 50% growth inhibition: 2070 nM
The estimate for compound 3 lay 1.2-fold (0.08 log units) above the measured number, within the range that was stated.
By their numbers in this assay, from the lowest: compounds 3, 2 and 1 (each within the scatter of the next).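

In this assay, the earlier pair altered only what sits on the ring oxygen, whereas here the oxygen itself is gone, and 4-hydroxyphenyl to 4-chlorophenyl gives a 1.2-fold lower number from compound 2 to compound 3 (0.09 log units; within the scatter) at this position. Chloro in place of methoxy gives a 1.3-fold lower number from compound 1 to compound 3 (0.12 log units; within the scatter) and is likewise no readable difference, so at this position, in these three compounds, a group counted with a hydrogen-bond donor and acceptor and one counted with neither cannot be told apart. Nothing available here speaks to the reason these numbers stay so close.

As far as these compounds go, all three groups give numbers within the scatter of one another, so it remains open whether an amine, a carboxylic acid or a longer chain here would give a step beyond the scatter. The compounds shown also leave open whether other places on the shared core would respond any differently.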